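A few compounds are considered here, and "the series" means these few. Any claim that something is new, unique, unknown or untested is made for them only; others in the source may bear on it.

Three compounds share one core, and in an assay for displacement of a labelled ligand from adenosine receptor A1 (Rattus norvegicus) (on this read-out higher numbers stand for weaker inhibition and lower numbers for stronger inhibition), they spread widely. Compound 1, with the structure `CCC(Sc1nc(S)c2cnn(-c3ccccc3)c2n1)C(N)=O`, gives 155 nM and so stands with the highest number of the three. Compound 2, `CCCCC(Sc1nc(N)c2cnn(-c3ccccc3)c2n1)C(N)=O`, gives 0.939 nM in this assay, the lowest number among them, and compound 3, `CSc1nc(SC(C(N)=O)C(C)C)nc2c1cnn2-c1ccccc1`, gives 15.7 nM in this assay. Compound 3 is the nearest neighbour of compound 1 in these numbers, yet its value lies beyond the scatter below it, and compound 2 lies further still.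

Compound 4, `CCC(Sc1nc(SC)c2cnn(-c3ccccc3)c2n1)C(N)=O`, is not yet measured. For the measured compounds named here, it differs from compound 1 by methyl in place of hydrogen on a sulfur, which is the same change of the sulfanyl group that compound 3 also carries, though compound 3 bears a different side chain as well, so no clean single step exists. On the two values of compound 1 and compound 3 alone, a lowering of the number is expected in this assay. Compound 4 is therefore estimated at 40 nM, within 10 nM to 150 nM, an expected step of a 3.9-fold lower number from compound 1 to compound 4 (0.59 log units; beyond the scatter).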

Compound 4, inhibition constant: 8.4 nM
Estimate against measurement, compound 4: 4.8-fold (0.68 log units) above; measured number outside the range, below it.
By their numbers in this assay, from the lowest: compound 2; then compounds 4 and 3 (each within the scatter of the next); then compound 1.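

In this assay, methyl in place of hydrogen on a sulfur whose other neighbour is an aromatic carbon gives an 18-fold lower number from compound 1 to compound 4 (1.27 log units; beyond the scatter) with the side chain unchanged, so this pair isolates the sulfanyl to methylsulfanyl change, and the change is large. The other new comparison, hydrogen in place of methyl on a saturated chain carbon bound to two saturated chain carbons, gives a 1.9-fold lower number from compound 3 to compound 4 (0.27 log units; within the scatter) and stays within the scatter, so the two side chains are not told apart when methylsulfanyl is present. Nothing available bears on the reason for the large step.

Going by these compounds, whether an ethyl or benzyl group on that sulfur, or a methoxy group in place of methylsulfanyl, would give a similar number remains open. Compound 2, which carries an amine, differs from compound 4 in more than one place and cannot settle this.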